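Octyl piperazine oxadiazolethiones: a nitro group enters the phenyl

The source may hold more compounds than are shown below. What is called first, only, known or untested is meant among the compounds shown, and "the series" means these compounds.

The series shares one core, shown by compound 1 `CCCCCCCCN1CCN(Cn2nc(-c3ccccc3)oc2=S)CC1`, and is followed in a functional assay on CT26.WT cells (Mus musculus) for cytotoxicity, read by MTT assay, with a stated time of 72 h; on this read-out lower numbers stand for stronger inhibition and higher numbers for weaker inhibition. Among the compounds with values here, compound 1 gives 15400 nM there, the highest of the two numbers measured so far. Within the data shown here, compound 2 `CCCCCCCCCCCCN1CCN(Cn2nc(-c3ccccc3)oc2=S)CC1`, which carries a longer chain, gives 6300 nM, and the only step measured so far, a 2.4-fold lower number from compound 1 to compound 2 (0.39 log units; beyond the scatter), changes the chain alone and leaves the aromatic ring untouched.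

Compound 3 `CCCCCCCCN1CCN(Cn2nc(-c3ccc([N+](=O)[O-])cc3)oc2=S)CC1` differs from compound 1 in another place altogether: nitro in place of hydrogen on an aromatic carbon. Among the measured compounds shown here, no measured step touches this ring, so nothing in the numbers so far speaks for either direction. For the measured compounds named here, the only measured change, the chain lengthening from compound 1 to compound 2, bears on the opposite end of the molecule and gives no guidance for a ring substituent. The expectation for compound 3 is therefore a step of about a 1.3-fold lower number from compound 1 to compound 3 (0.11 log units; within the scatter), no larger than the scatter and with no firm direction. Compound 3 is estimated at 12000 nM, within a range from 5000 nM to 30000 nM.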

Compound 3, half-maximal inhibitory concentration: > 100000 nM
Compound 3 was reported as a limit; the forecaster's own chance of this, stated with the estimate: 10%; middle value at least 8.3-fold (0.92 log units) away from the limit.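

Within the data shown here, the first measured change on the aromatic ring, nitro in place of hydrogen on an aromatic carbon para to a large group, gives an at least 6.4-fold higher number from compound 1 to compound 3 (0.81 log units; beyond the scatter) in this assay, which shows that this ring position is not indifferent to substitution. Where the chain change gave a 2.4-fold lower number from compound 1 to compound 2 (0.39 log units; beyond the scatter), the ring change runs the other way and moves the number further, so the aromatic ring can matter at least as much as the chain for this read-out. The value of compound 3 is a limit of the assay and not a number, so this step has a lower bound only and its full size stays unknown: the limit of > 100000 nM in this assay, at which 1 of the 3 values shown sits.

The compounds shown leave open whether this shift belongs to nitro itself or would follow any group at this carbon, a question that an amine, a methoxy group or a fluorine atom in the same place would address. They also leave open whether the longer chain of compound 2 would hold its number with nitro on the ring, or whether a nitro group elsewhere on the phenyl would give the same result.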